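A few compounds are considered here, and "the series" means these few. Any claim that something is new, unique, unknown or untested is made for them only; others in the source may bear on it.

In a functional assay on HL-60 cells (Homo sapiens) for antiproliferative activity, with a stated time of 72 h (on this read-out lower numbers stand for stronger inhibition and higher numbers for weaker inhibition), three compounds built on a shared core have been measured. Compound 1 `CCCCC#Cc1cc([C@@H]2O[C@H](CO)[C@@H](O)[C@H]2O)n2ncnc(N)c12` gives 400 nM, compound 2 `Nc1ncnn2c([C@@H]3O[C@H](CO)[C@@H](O)[C@H]3O)cc(C#CC3CC3)c12` gives 40 nM, and compound 3 `Cc1ccccc1-c1cc([C@@H]2O[C@H](CO)[C@@H](O)[C@H]2O)n2ncnc(N)c12` gives 48400 nM, the highest of the three numbers. Compound 4 `Nc1ncnn2c([C@@H]3O[C@H](CO)[C@@H](O)[C@H]3O)cc(-c3ccoc3)c12` has not yet been measured. It carries furan-3-yl in place of 2-methylphenyl on an aromatic carbon of the five-membered aromatic ring with 1 nitrogen (furan-3-yl in place of 2-methylphenyl on an aromatic carbon).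

Among the measured compounds shown here, no measured step exchanges one aromatic ring for another, so the evidence is indirect. Two large steps involve 2-methylphenyl at this place: a 120-fold higher number from compound 1 to compound 3 (2.08 log units; beyond the scatter) and a 1200-fold higher number from compound 2 to compound 3 (3.08 log units; beyond the scatter). A modest step between the two alkynes, a 10-fold lower number from compound 1 to compound 2 (1.00 log units; beyond the scatter), also shows that the number responds to the group here. Compound 3 therefore gives no assurance that a different aromatic ring would stay as high, and a large step to a lower number is expected, with considerable uncertainty. The expected change is a 120-fold lower number from compound 3 to compound 4 (2.08 log units; beyond the scatter). For compound 4 the estimated value is 400 nM, with an expected range from 40 nM to 6000 nM.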

Compound 4, half-maximal inhibitory concentration: 500 nM
For compound 4 the middle estimate is 1.3-fold (0.10 log units) below the measured one, and the stated range covers the measured number.
By their numbers in this assay, from the lowest: compound 2; then compounds 1 and 4 (each within the scatter of the next); then compound 3.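

In this assay the exchange of 2-methylphenyl for furan-3-yl brings a 97-fold lower number from compound 3 to compound 4 (1.99 log units; beyond the scatter) and shows that an aromatic ring on this aromatic carbon need not give a number as high as that of compound 3. Furan-3-yl and hex-1-yn-1-yl cannot be told apart here, with a 1.3-fold higher number from compound 1 to compound 4 (0.10 log units; within the scatter) in this comparison, whereas 2-cyclopropylethynyl keeps the lowest number of the set, with a 13-fold higher number from compound 2 to compound 4 (1.10 log units; beyond the scatter) separating it from furan-3-yl. Nothing given here explains these differences.

On these data alone, how a phenyl ring without the methyl group would compare with 2-methylphenyl and furan-3-yl remains open. So does the effect of a simple amine or a carboxylic acid on this aromatic carbon.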